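The source may report more compounds than this note shows. Statements on the series, on what has been measured and on what is new or still open speak of the compounds shown alone.

Compound 1 `O=C(Nc1cccc(-c2cccc(F)c2)c1)C(Cl)Cl` holds the lowest number of the two measured compounds: in a functional assay on A549 cells (Homo sapiens) for cytotoxicity, read by MTT assay, with a stated time of 68 h (a higher number here means a weaker inhibitor, a lower number a stronger inhibitor), compound 1 gives 9530 nM, while compound 2 `CSc1ccc(-c2cc(NC(=O)C(Cl)Cl)cc(-c3ccc(SC)cc3)c2)cc1` gives 22300 nM, a gap beyond the scatter. Compound 3 `O=C(Nc1cccc(-c2ccccc2)c1)C(Cl)Cl` differs from compound 1 by hydrogen in place of fluoro on an aromatic carbon. Among the measured compounds shown here, no measured pair shows this change, so its effect cannot be read from the data. A small shift toward a weaker inhibitor, or none beyond the scatter, is expected, corresponding to a step of a 1.2-fold higher number from compound 1 to compound 3 (0.06 log units; within the scatter). Compound 3 is therefore expected to reach about 11000 nM in this assay, within 4500 nM to 28000 nM.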

Compound 3, half-maximal inhibitory concentration: 8900 nM
The estimate for compound 3 lay 1.2-fold (0.09 log units) above the measured number, within the range that was stated.
By their numbers in this assay, from the lowest: compounds 3 and 1 (each within the scatter of the next); then compound 2.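

In this assay, hydrogen in place of fluoro on this aromatic carbon, meta to a large group, gives a 1.1-fold lower number from compound 1 to compound 3 (0.03 log units; within the scatter) and so leaves the number unchanged within the scatter. At this place on the core of compound 1, the fluoro is thus shown to be dispensable for this cytotoxicity reading. No available evidence bears on this result. Going by these compounds, whether a methoxy group or an amine at the same place would shift the number beyond the scatter remains open.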